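The source may report more compounds than this note shows. Statements on the series, on what has been measured and on what is new or still open speak of the compounds shown alone.

Compound 1 `O=C(Nc1ccccc1)c1cnc(NCc2c(F)ccc3c2CCO3)n2cnnc12` was examined in a physicochemical assay for solubility, read by LC-MS, in phosphate buffer, with a stated time of 24 h, at pH 7.4; a lower number here means a less soluble compound, a higher number a more soluble compound. In this assay compound 1 gives < 1000 nM, which is a limit of the assay rather than a number (the limit of < 1000 nM in this assay, at which 1 of the 3 values shown sits). Two further compounds built on a different core were measured as well. Compound 2 `CNC(=O)c1ncc(-c2cnc(NCc3c(F)ccc4c3CCO4)c3cn[nH]c(=O)c23)n1C` gives 5000 nM in this assay. Compound 3 `CC(=O)N1CCC(c2cnc(NCc3c(F)ccc4c3CCO4)c3cn[nH]c(=O)c23)CC1` gives < 2000 nM, which is again a limit rather than a number (the limit of < 2000 nM in this assay, at which 1 of the 3 values shown sits). Among the compounds with values here, the only measured step, an at least 2.5-fold lower number from compound 2 to compound 3 (0.39 log units; beyond the scatter), is a drop of at least modest size on that other core.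

Compound 4 `C[C@@H]1CC(=O)N(c2cnc(NCc3c(F)ccc4c3CCO4)n3cnnc23)C1` has not yet been measured. It differs from compound 1 by 4-methyl-2-oxopyrrolidin-1-yl in place of phenylcarbamoyl on an aromatic carbon. Within the data shown here, no measured step covers this change or this core; the step from compound 2 to compound 3 involves other groups at another place and is therefore not a direct guide. Compound 1 already sits at a limit, so there is little room for a lower number. Compound 4 is expected to show an at least 2.0-fold higher number from compound 1 to compound 4 (0.30 log units; that floor lies within the scatter), with an estimated value of 2000 nM, between 500 nM and 8000 nM.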

Compound 4, solubility: 130000 nM
Estimate against measurement, compound 4: 65-fold (1.81 log units) below; the whole stated range lies below it.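

In this assay, replacing phenylcarbamoyl with 4-methyl-2-oxopyrrolidin-1-yl on the shared core gives an at least 130-fold higher number from compound 1 to compound 4 (2.11 log units; beyond the scatter). This is the only step shown at this position, and it shows that the number here can change far more than the single step on the other core suggested. The real size of the step is not fixed, since compound 1 stands at a limit of the assay rather than at a number: the limit of < 1000 nM in this assay, at which 1 of the 4 values shown sits.

This one change swaps several features at once: a six-membered aromatic ring of carbon only and a hydrogen-bond donor leave, while a five-membered non-aromatic ring with a defined stereocentre enters, so the compounds shown cannot say which of these matters. Going by these compounds, how a dimethylamino group or a carboxylic acid would read at this position also stays open.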